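From trifluoromethyl to bromo: what to expect

The source may report more compounds than this note shows. Statements on the series, on what has been measured and on what is new or still open speak of the compounds shown alone.

In an in vitro ADME assay on microsomes from liver (Homo sapiens) for pharmacokinetics, read by LC-MS, with a stated time of 10 min, tested at 1 uM (a lower number here means slower removal, a higher number faster removal of the compound), three compounds with a shared core give these values:
- compound 1 `CN1C[C@H](C(=O)Nc2ccccc2)[C@@H](c2ccc(/C=C/C(=O)Nc3ccccc3N)cc2)C1` gives 7 mL/min/kg
- compound 2 `CN1C[C@H](C(=O)Nc2ccc(C3CC3)cc2)[C@@H](c2ccc(/C=C/C(=O)Nc3ccccc3N)cc2)C1` gives 12 mL/min/kg
- compound 3 `CN1C[C@H](C(=O)Nc2ccc(C(F)(F)F)cc2)[C@@H](c2ccc(/C=C/C(=O)Nc3ccccc3N)cc2)C1` gives 6 mL/min/kg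

Compound 3 (6 mL/min/kg) stands level with the other two compounds, as neither of its steps leaves the usual scatter of repeated measurements. One is a 1.2-fold lower number from compound 1 to compound 3 (0.07 log units; within the scatter) and the other is a 2.0-fold lower number from compound 2 to compound 3 (0.30 log units; within the scatter) on the same scale.

Compound 4 `CN1C[C@H](C(=O)Nc2ccc(Br)cc2)[C@@H](c2ccc(/C=C/C(=O)Nc3ccccc3N)cc2)C1` has not yet been measured. It carries bromo in place of trifluoromethyl on an aromatic carbon, para to a large group (bromo in place of trifluoromethyl on an aromatic carbon).

Within the data shown here, no measured compound carries bromo, so the best guide is the set of changes already seen at that carbon. Besides the two steps above, there is a 1.7-fold higher number from compound 1 to compound 2 (0.23 log units; within the scatter) to consider. All three stay within the scatter, so no step beyond the scatter is expected in this assay and neither direction is favoured. The expected change is a 1.3-fold higher number from compound 3 to compound 4 (0.12 log units; within the scatter) as an estimate only.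

For compound 4 the estimated clearance is 8 mL/min/kg with an expected range from 4 mL/min/kg to 14 mL/min/kg around that estimate.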

Compound 4, clearance: 3 mL/min/kg
For compound 4 the middle estimate is 2.7-fold (0.43 log units) above the measured one; measured number below the stated range.
By their numbers in this assay, from the lowest: compounds 4, 3, 1 and 2 (each within the scatter of the next, the first and the last beyond it).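

In this assay, replacing trifluoromethyl (4 heavy atoms) with bromo (1 heavy atom) on this aromatic carbon gives a 2.0-fold lower number from compound 3 to compound 4 (0.30 log units; within the scatter), so these two groups cannot be told apart here. Among these compounds, what is new is that the position can now produce a difference larger than the usual scatter: bromo gives a 2.3-fold lower number from compound 1 to compound 4 (0.37 log units; beyond the scatter) against hydrogen and a 4.0-fold lower number from compound 2 to compound 4 (0.60 log units; beyond the scatter) against cyclopropyl, both modest, whereas no step among the first three compounds left the scatter, and compound 3, with trifluoromethyl, still stands within the scatter of both compound 1 and compound 2. Nothing available here explains why bromo separates from hydrogen and cyclopropyl while trifluoromethyl does not.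

The compounds shown leave open whether this lower clearance is particular to bromo or extends to other halogens such as chloro or fluoro, and how groups of a different kind, such as an amine, a methoxy group or a carboxylic acid, would behave on the same carbon. They also leave open whether bromo would give a similar result on a different core or on another carbon of this ring.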